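Oxazolidinone series: liver-cell cytotoxicity ahead of compound 4

A few compounds are considered here, and "the series" means these few. Any claim that something is new, unique, unknown or untested is made for them only; others in the source may bear on it.

Measured so far:
compound 1 `O=C1CNC(=O)N1C[C@H]1CN(c2ccc(-n3cc(-c4ccccn4)cn3)c(F)c2)C(=O)O1` sits at the limit > 400 ug/mL
compound 2 `COC[C@H]1CN(c2ccc(-n3cc(-c4ccccn4)cn3)c(F)c2)C(=O)O1` sits at the limit > 400 ug/mL
compound 3 `CCNC(=O)NC[C@H]1CN(c2ccc(-n3cc(-c4ccccn4)cn3)c(F)c2)C(=O)O1` sits at the limit > 400 ug/mL

Among the compounds with values here, in an ADME assay on L02 cells (Homo sapiens) for cytotoxicity, read by MTT assay, with a stated time of 48 h (a higher number here means a weaker inhibitor, a lower number a stronger inhibitor), every value so far is a limit of the assay, not a number, so compound 3 stands where compound 1 and compound 2 stand, with no readable separation. The steps that change the same side chain, a step that the two limits leave unreadable from compound 1 to compound 3 and a step that the two limits leave unreadable from compound 2 to compound 3, have no readable size because of the limit of > 400 ug/mL in this assay, at which 3 of the 3 values shown sit.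

Compound 4 `NC(=O)[C@H]1CN(c2ccc(-n3cc(-c4ccccn4)cn3)c(F)c2)C(=O)O1` differs from compound 3 by carbamoyl in place of ((ethylcarbamoyl)amino)methyl on a saturated ring carbon. With nothing but limits behind it, no step beyond the scatter in this assay can be expected; compound 4 is expected to sit again at or around the limit, 400 ug/mL with a range of 200 ug/mL to 800 ug/mL, and the step of a number no higher from compound 3 to compound 4 (the limit leaves the size open) is estimated to stay within the scatter.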

Compound 4, half-maximal inhibitory concentration: 119 ug/mL
For compound 4 the middle estimate is 3.4-fold (0.53 log units) above the measured one; the measured number lies below the stated range.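

Of the compounds shown, only compound 4 gives a number rather than a limit: the limit of > 400 ug/mL in this assay, at which 3 of the 4 values shown sit. In this assay, carbamoyl on this saturated ring carbon gives an at least 3.3-fold lower number from compound 3 to compound 4 (0.52 log units; beyond the scatter), an at least 3.3-fold lower number from compound 2 to compound 4 (0.52 log units; beyond the scatter) and an at least 3.3-fold lower number from compound 1 to compound 4 (0.52 log units; beyond the scatter), so the group at this position can move the read-out beyond the scatter. The steps among compound 1, compound 2 and compound 3 cannot be read.

As far as these compounds go, the true size of the three readable steps stays open, as does whether the change follows from carbamoyl itself or from the missing methyl link. A carboxylic acid or an aminomethyl group at this ring carbon would be needed to separate the two.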